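Benzylamino amide in the dienyl alcohol series

The source may hold more compounds than are shown below. What is called first, only, known or untested is meant among the compounds shown, and "the series" means these compounds.

Measured in a functional assay on MCF7 cells (Homo sapiens) for antiproliferative activity, read by sulforhodamine B assay, with a stated time of 48 h; on this read-out lower numbers stand for stronger inhibition and higher numbers for weaker inhibition:
- compound 1 `COc1ccc(C[C@@H](O)/C=C/C=C/C(=O)NCc2ccc(Cl)cc2)cc1OC`: 18100 nM
- compound 2 `CCN1CCN(C(=O)/C=C/C=C/[C@H](O)Cc2ccc(OC)c(OC)c2)CC1`: 11500 nM
- compound 3 `COc1ccc(C[C@@H](O)/C=C/C=C/C(=O)N2CCCC2)cc1OC`: 26200 nM

Compound 3 lies within the scatter of compound 1, as a 1.4-fold higher number from compound 1 to compound 3 (0.16 log units; within the scatter) shows. Its separation from compound 2 is beyond the scatter but modest: a 2.3-fold higher number from compound 2 to compound 3 (0.36 log units; beyond the scatter).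

The next compound is compound 4 `COc1ccc(C[C@@H](O)/C=C/C=C/C(=O)NCc2ccccc2)cc1OC`, which carries benzylamino in place of pyrrolidin-1-yl on a carbonyl carbon.

The most relevant measured step is a 1.4-fold higher number from compound 1 to compound 3 (0.16 log units; within the scatter), which links pyrrolidin-1-yl to (4-chlorobenzyl)amino at the same place. Going by the values given here, compound 4 differs from compound 1 only by the missing chloro group, and no measured pair isolates that change. The step of a 1.6-fold lower number from compound 1 to compound 2 (0.20 log units; within the scatter) is also small. The pair of compound 2 and compound 3 is the one exception to this flat picture, and even there the step is modest. On this evidence, this assay is expected to show no step beyond the scatter, with a slight lean toward a lower number, in line with compound 1 at 18100 nM.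

The expected step is a 1.2-fold lower number from compound 3 to compound 4 (0.10 log units; within the scatter).

Compound 4 is estimated at 21000 nM, with an expected range of 11000 nM to 38000 nM.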

Compound 4, half-maximal inhibitory concentration: 33600 nM
For compound 4 the middle estimate is 1.6-fold (0.20 log units) below the measured one; measured number inside the range.
By their numbers in this assay, from the lowest: compounds 2, 1, 3 and 4 (each within the scatter of the next, the first and the last beyond it).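

In this assay, benzylamino on the carbonyl carbon stays within the scatter of pyrrolidin-1-yl, with a 1.3-fold higher number from compound 3 to compound 4 (0.11 log units; within the scatter) as the step, so the aromatic ring and the amide hydrogen that enter here do not separate the two amides. Going by these compounds alone, this pair also isolates hydrogen in place of chloro on an aromatic carbon for the first time: a 1.9-fold higher number from compound 1 to compound 4 (0.27 log units; within the scatter) is the step, so the chloro group cannot be credited with any real gain on this read-out. Within the data shown here, the only step beyond the scatter in this set involving the new compound is a 2.9-fold higher number from compound 2 to compound 4 (0.47 log units; beyond the scatter) with 4-ethylpiperazin-1-yl as the group replaced, and it remains modest, while nothing at hand accounts for it or for the flat steps around it.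

Still open, from the compounds shown here alone, is whether a morpholin-4-yl group, an unsubstituted piperazin-1-yl group or a longer chain ending in a primary amine on the carbonyl carbon would move the number well beyond the scatter. All four compounds also keep the rest of the core unchanged, so replacing the hydroxyl group or either methoxy group remains an untested route to a larger step in this series.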